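The source may report more compounds than this note shows. Statements on the series, on what has been measured and on what is new or still open speak of the compounds shown alone.

Compound 1, `COc1ccc2[nH]c(C(=O)N3CC(=O)N(Cc4ccccc4)[C@@H](CN4CCC5(CC4)CC5)C3)cc2c1`, gives in an ADME assay on Vero cells (Chlorocebus sabaeus) for cytotoxicity, with a stated time of 7 days (on this read-out lower numbers stand for higher toxicity in this test and higher numbers for lower toxicity in this test), a value of 17100 nM.
Compound 2, `COc1ccc2[nH]c(C(=O)N3CC(=O)N(Cc4ccccc4)[C@@H](CN4CCN(c5ccccn5)CC4)C3)cc2c1`, gives in this assay only a limit, > 30000 nM.
Compound 3, `COc1ccc2[nH]c(C(=O)N3CC(=O)N(Cc4ccccc4)[C@@H](CN4CCn5cccc5C4)C3)cc2c1`, gives in this assay only a limit, > 100000 nM.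

Compound 3 therefore stands at the upper edge of this assay: its number is not known, only that it lies past (the limit of > 100000 nM in this assay, at which 1 of the 3 values shown sits). Compound 2 likewise reached a limit, (the limit of > 30000 nM in this assay, at which 1 of the 3 values shown sits). Of the three measured steps, all swap the same group at the same place, the saturated chain carbon bound to a saturated ring carbon. The step of an at least 5.8-fold higher number from compound 1 to compound 3 (0.76 log units; beyond the scatter) is the only one clearly beyond the scatter; the step of an at least 1.7-fold higher number from compound 1 to compound 2 (0.24 log units; that floor lies within the scatter) is within it; the step that the two limits leave unreadable from compound 2 to compound 3 cannot be read, since both ends are limits.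

Compound 4, `COc1ccc2[nH]c(C(=O)N3CC(=O)N(Cc4ccccc4)[C@@H](CN4CCCc5ccccc54)C3)cc2c1`, differs from compound 3 in that same place: a group of 10 heavy atoms (9 carbon, 1 nitrogen; one six-membered non-aromatic ring with 1 hetero atom, one six-membered aromatic ring of carbon only) in place of a group of 9 heavy atoms (7 carbon, 2 nitrogen; one five-membered aromatic ring with 1 hetero atom, one six-membered non-aromatic ring with 2 hetero atoms), on a saturated chain carbon bound to a saturated ring carbon. Among the measured compounds shown here, no measured step makes exactly this exchange, so the direction rests on little. Since compound 3 sits at the limit of > 100000 nM in this assay, at which 1 of the 3 values shown sits, any step from it that is readable in this assay would be a lower number, that is, higher toxicity; a step within the scatter, or another limit, is also possible. Compound 4 is estimated at 40000 nM, with a range of 10000 nM to 100000 nM. That estimate means a step of an at least 2.5-fold lower number from compound 3 to compound 4 (0.39 log units; beyond the scatter).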

Compound 4, half-maximal cytotoxic concentration: > 100000 nM
Compound 4: no number, only a limit; the forecaster's own chance of this, stated with the estimate: 40%; at least 2.5-fold (0.39 log units) between middle value and limit.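

In this assay compound 4 gives only a limit, the same one as compound 3: the limit of > 100000 nM in this assay, at which 2 of the 4 values shown sit.

So at this place, on a saturated chain carbon bound to a saturated ring carbon, a second group reaches the top of the read-out, and this one carries a six-membered aromatic ring of carbon only and 1 nitrogen where the group of compound 3 has a five-membered aromatic ring and 2 nitrogens; for these two compounds, neither that five-membered ring nor the extra nitrogen is needed to stay at the limit. Among the compounds shown here, the one step that can be read, an at least 5.8-fold higher number from compound 1 to compound 4 (0.76 log units; beyond the scatter), shows that the 1,2,3,4-tetrahydroquinolin-1-yl group is clearly less toxic in this test than the group of compound 1, while the steps among compounds 2, 3 and 4 cannot be read, since both ends are limits.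

From the compounds shown here alone, how far compounds 2, 3 and 4 lie past their limits stays unknown, so no order among them can be given. Also open, going by these compounds, is whether a small open-chain amine such as dimethylamino at this place, or a carboxylic acid on the aromatic ring of the 1,2,3,4-tetrahydroquinolin-1-yl group, would give a measurable number.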